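The source may hold more compounds than are shown below. What is called first, only, known or untested is meant among the compounds shown, and "the series" means these compounds.

Working notes on a three-compound series sharing one core. Compound 1 `CC(=O)OCCC(=O)O[C@H](CC=C(C)C)C1=CC(=O)c2c(O)ccc(O)c2C1=O` in a functional assay on HeLa cells (Homo sapiens) for cytotoxicity, read by MTT assay (on this read-out lower numbers stand for stronger inhibition and higher numbers for weaker inhibition), gives 17300 nM. Compound 2 `CC(=O)OCCO[C@H](CC=C(C)C)C1=CC(=O)c2c(O)ccc(O)c2C1=O` gives 41500 nM. Compound 3 `CC[C@@](C)(O)CC(=O)O[C@H](CC=C(C)C)C1=CC(=O)c2c(O)ccc(O)c2C1=O` gives 17900 nM. On these numbers compound 3 stands second highest of three: the step of a 1.0-fold higher number from compound 1 to compound 3 (0.01 log units; within the scatter) is the smallest gap in the set, while a 2.3-fold lower number from compound 2 to compound 3 (0.37 log units; beyond the scatter) is the largest.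

Compound 4 `CC(C)=CC[C@@H](OC(=O)C1CCCO1)C1=CC(=O)c2c(O)ccc(O)c2C1=O` is not yet measured. Its change from compound 3: oxolan-2-yl in place of 2-hydroxy-2-methylbutyl on a carbonyl carbon. The step of a 1.0-fold higher number from compound 1 to compound 3 (0.01 log units; within the scatter) also reworked the group on this carbonyl carbon and lay within the scatter; the remaining steps, a 2.4-fold higher number from compound 1 to compound 2 (0.38 log units; beyond the scatter) and a 2.3-fold lower number from compound 2 to compound 3 (0.37 log units; beyond the scatter), were only modest. No step beyond the scatter is therefore expected in this assay; the expected step is a 1.0-fold higher number from compound 3 to compound 4 (0.00 log units; within the scatter). Compound 4 is estimated at 18000 nM, with a range of 8000 nM to 40000 nM.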

Compound 4, half-maximal inhibitory concentration: 17000 nM
Estimate against measurement, compound 4: 1.1-fold (0.02 log units) above, and the stated range covers the measured number.
By their numbers in this assay, from the lowest: compounds 4, 1 and 3 (each within the scatter of the next); then compound 2.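

In this assay, a ring without a hydrogen-bond donor on this carbonyl carbon is tolerated: oxolan-2-yl in place of 2-hydroxy-2-methylbutyl gives a 1.1-fold lower number from compound 3 to compound 4 (0.02 log units; within the scatter), and oxolan-2-yl in place of 2-acetoxyethyl gives a 1.0-fold lower number from compound 1 to compound 4 (0.01 log units; within the scatter). Compound 2, with 2-acetoxyethyl directly on the oxygen and no carbonyl, remains apart, with a 2.4-fold lower number from compound 2 to compound 4 (0.39 log units; beyond the scatter) as the step. No measured data explaining these steps are available. From the compounds shown here alone, whether an amine or a carboxylic acid on this carbonyl carbon would shift the number beyond the scatter remains open, as does the effect of a six-membered ring or a longer chain.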